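This account rests on a few compounds, and the source may have more. Where it says the series, first, only, none or still open, it means among the compounds named here.

Measured so far in an ADME assay on microsomes from liver (Mus musculus) for metabolic stability, read by LC-MS, using NADPH; a higher number here means that the compound lasts longer, a lower number that the compound disappears faster:
Compound 1 `O=C(Nc1cc(C(F)(F)F)cc(C(F)(F)F)c1)c1cc(Br)c(-c2ccccc2)cc1O`: 2.65 h
Compound 2 `N#Cc1ccc(NC(=O)c2ccc3cccnc3c2O)cc1`: 2.61 h
Compound 3 `O=C(Nc1cc(C(F)(F)F)cc(C(F)(F)F)c1)c1ccc(Cl)cc1O`: 0.53 h

Compound 3 stands lowest of the three in this assay, and compound 1 and compound 2 both lie above it by more than the usual scatter. Compound 4 `O=C(Nc1cc(C(F)(F)F)cc(C(F)(F)F)c1)c1cc(Br)ccc1O` has not yet been measured. It carries 5-bromo-2-hydroxyphenyl in place of 4-chloro-2-hydroxyphenyl on a carbonyl carbon. Within the data shown here, no measured pair differs in one place only, so no direct precedent exists for this change. A modest rise is expected because compound 3 at 0.53 h sits at the bottom of the measured range. The expected step is a 1.7-fold higher number from compound 3 to compound 4 (0.23 log units; within the scatter), which would be close to the usual scatter. For compound 4 the estimate is 0.9 h, with an expected range of 0.35 h to 2.6 h.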

Compound 4, half-life: 0.485 h
Compound 4: middle estimate off by 1.9-fold (0.27 log units), on the high side; measured number inside the range.
By their numbers in this assay, from the lowest: compounds 4 and 3 (each within the scatter of the next); then compounds 2 and 1 (each within the scatter of the next).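

In this assay, 5-bromo-2-hydroxyphenyl in place of 4-chloro-2-hydroxyphenyl on a carbonyl carbon gives a 1.1-fold lower number from compound 3 to compound 4 (0.04 log units; within the scatter) and so does not separate the two compounds. Hydrogen in place of phenyl on an aromatic carbon gives a 5.5-fold lower number from compound 1 to compound 4 (0.74 log units; beyond the scatter) and is the first single change here that goes beyond the scatter. The evidence at hand offers no explanation for either step.

The compounds shown leave open whether a methyl group or an amine in place of that phenyl would stand with compound 1 or with compound 4.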